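The source may report more compounds than this note shows. Statements on the series, on what has been measured and on what is new or still open speak of the compounds shown alone.

Compound 1 `O=C1NCCN1CCOc1nn(-c2ccccc2F)c2ccc(F)cc12`: 183 mL/min/kg
Compound 2 `O=C1OCCN1CCOc1nn(-c2ccccc2F)c2ccc(F)cc12`: 683 mL/min/kg

For the measured compounds named here, in an ADME assay on liver for metabolic stability, with Liver microsome (Homo sapiens) as the target, using microsomes and NADPH, with a stated time of 30 min, tested at 0.5 uM (a higher number here means faster removal of the compound, a lower number slower removal), compound 1 gives 183 mL/min/kg, the lower of the two numbers so far. Compound 3 `O=C1NCCN1CCOc1nn(-c2ccc(F)cc2)c2ccc(F)cc12` has 4-fluorophenyl in place of 2-fluorophenyl on an aromatic nitrogen of compound 1 (4-fluorophenyl in place of 2-fluorophenyl on an aromatic nitrogen). Going by the values given here, the only measured step, a 3.7-fold higher number from compound 1 to compound 2 (0.57 log units; beyond the scatter), is beyond the scatter, but it is a change on a saturated chain carbon and leaves the 2-fluorophenyl untouched. It shows that one swap can matter, yet it gives no direction here. The expected change is therefore none beyond the scatter: a 1.1-fold higher number from compound 1 to compound 3 (0.04 log units; within the scatter). The estimate for compound 3 is 200 mL/min/kg, with an expected range of 90 mL/min/kg to 450 mL/min/kg.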

Compound 3, clearance: 66.7 mL/min/kg
For compound 3 the middle estimate is 3.0-fold (0.48 log units) above the measured one; the whole stated range lies above it.
By their numbers in this assay, from the lowest: compound 3; then compound 1; then compound 2.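

Moving the fluorine matters in this assay: 4-fluorophenyl in place of 2-fluorophenyl gives a 2.7-fold lower number from compound 1 to compound 3 (0.44 log units; beyond the scatter), towards slower removal. The two groups have the same atoms, so this place on the aromatic nitrogen responds to how the group is arranged, not only to what it contains. Nothing measured here bears on why the number falls. Still open, from the compounds shown here alone, is how a plain phenyl or a pyridine ring would compare at this place. Also open, going by these compounds, is whether 4-fluorophenyl gives a similar step alongside the 2-oxo-1,3-oxazolidin-3-yl group of compound 2.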